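The source may report more compounds than this note shows. Statements on the series, on what has been measured and on what is new or still open speak of the compounds shown alone.

Two compounds built on the same sugar-bearing core have been run in a functional assay on G-361 cells (Homo sapiens) for antiproliferative activity, with a stated time of 72 h; a higher number here means a weaker inhibitor, a lower number a stronger inhibitor. Compound 1, `OC[C@H]1O[C@@H](n2cnc3c(NCc4ccccc4Br)ncnc32)[C@H](O)[C@@H]1O`, carries a 2-bromophenyl on the chain carbon that joins the core. In this assay compound 1 reaches only the limit of > 166000 nM, so no number is known for it, just that its potency lies beyond what the assay could report; this is the limit of the limit of > 166000 nM in this assay, at which 1 of the 2 values shown sits. Compound 2, `COc1ccc(CNc2ncnc3c2ncn3[C@@H]2O[C@H](CO)[C@@H](O)[C@H]2O)c(OC)c1`, carries a 2,4-dimethoxyphenyl at the same place. In this assay compound 2 returned "not determined" (no result reported), so it stands without a number.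

Compound 3, `OC[C@H]1O[C@@H](n2cnc3c(NCc4ccccc4OC(F)F)ncnc32)[C@H](O)[C@@H]1O`, is not yet measured. It differs from compound 2 in one place: 2-(difluoromethoxy)phenyl in place of 2,4-dimethoxyphenyl on a saturated chain carbon bound to a nitrogen on an aromatic ring. Within the data shown here, no measured step between two compounds is available to guide the size of this change, so no direction beyond the scatter can be claimed for it in this assay.

Compound 3 is expected to sit near 150000 nM, within a range from 40000 nM to 500000 nM, an estimate resting on compound 1 reaching > 166000 nM.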

Compound 3, half-maximal inhibitory concentration: > 166000 nM
Compound 3: no number, only a limit; the forecaster's own chance of this, stated with the estimate: 70%; middle value at least 1.1-fold (0.04 log units) away from the limit.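

In this assay compound 3, like compound 1, ends at a limit and not at a number: the limit of > 166000 nM in this assay, at which 2 of the 3 values shown sit.

Among these compounds, no step from compound 1 to compound 3 can be read from these two limits. The compounds shown leave open whether any group at this place gives a measurable value at all.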